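This account rests on a few compounds, and the source may have more. Where it says the series, first, only, none or still open, it means among the compounds named here.

Compounds measured so far:
compound 1 `CCCCc1cnc(C(CC)Cc2ccc(-c3ccccc3C(=O)O)cc2)[nH]1` — 2720 nM
compound 2 `O=C(O)c1ccccc1-c1ccc(CCc2ncc(CC3CCCCCC3)[nH]2)cc1` — 88 nM
compound 3 `CCCCc1cnc(CCCc2ccc(-c3ccccc3C(=O)O)cc2)[nH]1` — 5600 nM

Three compounds sharing a core have been run in an in vitro functional assay on cells for agonist activity at Bombesin receptor subtype-3 (Homo sapiens), read by luminescence and calcium flux; a lower number here means that less compound is needed, a higher number that more compound is needed for the effect. Compound 2 gives the lowest number of the three, at 88 nM. The nearest of the others is compound 1, at 2720 nM, and the gap to it lies beyond the usual scatter of this assay. Compound 3 sits further away still, at 5600 nM, again well beyond the scatter. Compound 2 therefore stands clearly apart from compounds 1 and 3 on the numbers in hand.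

The next compound, compound 4 `O=C(O)c1ccccc1-c1ccc(CCc2ncc(CCc3ccccc3)[nH]2)cc1`, takes compound 2 as its point of departure. The change is benzyl in place of cycloheptyl on a saturated chain carbon bound to an aromatic carbon. For the measured compounds named here, no pair of measured compounds differs in only this one place, so there is no direct precedent for the size of this step in this assay.

The account expects the step from compound 2 to compound 4 to move the number upward, beyond the scatter, though not as far as the distance separating compound 2 from compound 1, because the value of compound 2 in this assay, 88 nM, is the only firm anchor. On this basis compound 4 is estimated at 400 nM, with a range from 100 nM to 2000 nM, an expected step of a 4.5-fold higher number from compound 2 to compound 4 (0.66 log units; beyond the scatter).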

Compound 4, half-maximal effective concentration: 1320 nM
For compound 4 the middle estimate is 3.3-fold (0.52 log units) below the measured one; the range from low to high includes it.
By their numbers in this assay, from the lowest: compound 2; then compound 4; then compound 1; then compound 3.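

In this assay, for the compounds shown here, the change of cycloheptyl to benzyl on a saturated chain carbon bound to an aromatic carbon gives a 15-fold higher number from compound 2 to compound 4 (1.18 log units; beyond the scatter) and is the first step in this set that alters one place only, showing that this position is far from indifferent to the group it carries. The size of the step is striking since the two groups match in what can be counted: each has the same number of heavy atoms, all carbon, with no hydrogen-bond donors or acceptors and no net charge, while a seven-membered non-aromatic ring gives way to a six-membered aromatic one and, cut one bond further out, cycloheptylmethyl becomes phenethyl. Nothing at hand accounts for why the number rises.

The step changes the ring and its distance from the core together, so the compounds shown leave open which of the two matters. A cyclohexylethyl or a phenyl at this position would begin to pull these two changes apart.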